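Swapping a halogen for a methoxy group on a chalcone

The source may report more compounds than this note shows. Statements on the series, on what has been measured and on what is new or still open speak of the compounds shown alone.

The study concerns two measured chalcone-type compounds and another that has not yet been tested. Compound 1 `C=CCOc1cc(OC)c(C(=O)/C=C/c2ccc(F)cc2)c(OCC=C)c1` and compound 2 `COc1cc(O)cc(O)c1C(=O)/C=C/c1ccc(Cl)cc1` were both assessed in a toxicity assay on cells (Macrophage, Mus musculus, strain BALB/c) for cytotoxicity, read by MTT assay; a lower number here means a stronger inhibitor, a higher number a weaker inhibitor. There, compound 1 gives 13800 nM, and compound 2 gives 19000 nM; the two numbers lie within the usual scatter of each other, so neither can be told apart from the other on this evidence. Compound 1 is the parent for the step that is followed here.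

Compound 3 `C=CCOc1cc(OC)c(C(=O)/C=C/c2cccc(OC)c2)c(OCC=C)c1` differs from compound 1 in a single place: 3-methoxyphenyl in place of 4-fluorophenyl on a double-bonded chain carbon bound to a double-bonded chain carbon. For the measured compounds named here, no step between measured compounds that differ in one place is available, so the effect of this change has to be expected from the two numbers alone, which sit close together despite differing aromatic substituents. On that basis the step from compound 1 to compound 3 is expected to be small, a 1.1-fold higher number from compound 1 to compound 3 (0.04 log units; within the scatter), in no firm direction beyond the scatter. Compound 3 is therefore estimated to give 15000 nM in this assay, with a plausible range from 6000 nM to 40000 nM.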

Compound 3, half-maximal inhibitory concentration: 13100 nM
Compound 3: middle estimate off by 1.1-fold (0.06 log units), on the high side, within the range that was stated.
By their numbers in this assay, from the lowest: compounds 3, 1 and 2 (each within the scatter of the next).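

For the compounds shown here, the step gives the only direct reading at this place, on a double-bonded chain carbon bound to a double-bonded chain carbon: in this assay, 3-methoxyphenyl in place of 4-fluorophenyl amounts to a 1.1-fold lower number from compound 1 to compound 3 (0.02 log units; within the scatter), so the two groups cannot be told apart here. Compound 1 and compound 2 differ in more than one place and could not show this, whereas compound 1 and compound 3 share the same core and differ only in this aromatic group, which goes from 7 heavy atoms and 0 hydrogen-bond acceptors to 8 heavy atoms and 1 hydrogen-bond acceptor. No measurement at hand offers an explanation for this result.

The step exchanges both the substituent and its printed ring number at once, so a 4-methoxyphenyl or a 3-fluorophenyl group at this place would be needed to separate the two. From the compounds shown here alone, it also remains open whether a group of a different kind would give a value distinguishable from that of compound 1, such as a phenyl ring carrying an amine or a carboxylic acid, or a longer chain in place of the ring.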